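Side-chain variation at the sulfur-bound carbon: compound 3 in view

This account rests on a few compounds, and the source may have more. Where it says the series, first, only, none or still open, it means among the compounds named here.

Measured compounds:
compound 1 `C#CCSc1nc2cc(Cl)c(Cl)cc2n1C1O[C@H](CO)[C@@H](O)[C@H]1O`: 60000 nM
compound 2 `COc1ccc(CSc2nc3cc(Cl)c(Cl)cc3n2C2O[C@H](CO)[C@@H](O)[C@H]2O)cc1`: 41000 nM

In a functional assay on KB cells (Homo sapiens) for inhibition (a lower number here means a stronger inhibitor, a higher number a weaker inhibitor), compound 1 gives 60000 nM, and compound 2 gives 41000 nM. Among the compounds with values here, the only step known, a 1.5-fold lower number from compound 1 to compound 2 (0.17 log units; within the scatter), is a change at the same place as the one now considered. Compound 2 thus has one neighbour, compound 1, and both values sit inside the scatter; no ranking is possible.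

Compound 3 `OC[C@H]1OC(n2c(SCc3cccc(Cl)c3)nc3cc(Cl)c(Cl)cc32)[C@H](O)[C@@H]1O` differs from compound 2 by 3-chlorophenyl in place of 4-methoxyphenyl on a saturated chain carbon bound to a sulfur. Within the data shown here, with the one bearing step within the scatter, no movement in this assay beyond the scatter is expected for compound 3: a 1.0-fold lower number from compound 2 to compound 3 (0.01 log units; within the scatter). Compound 3 is therefore estimated at 40000 nM, with a range from 15000 nM to 110000 nM.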

Compound 3, half-maximal inhibitory concentration: 19000 nM
Compound 3: the middle estimate sits 2.1-fold (0.32 log units) above what was measured; the measured number falls inside the stated range.
By their numbers in this assay, from the lowest: compound 3; then compounds 2 and 1 (each within the scatter of the next).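

In this assay the group on a saturated chain carbon bound to a sulfur now moves the number beyond the scatter: 3-chlorophenyl gives a 2.2-fold lower number from compound 2 to compound 3 (0.33 log units; beyond the scatter) against 4-methoxyphenyl and a 3.2-fold lower number from compound 1 to compound 3 (0.50 log units; beyond the scatter) against ethynyl, both modest steps. Compound 3 is therefore the strongest of the three compounds shown. No evidence on the cause of these steps is available.

The compounds shown do not separate the identity of the ring substituent from its place on the ring. On these data alone, how a carboxylic acid, an amine or a longer chain on the sulfur would read also remains open.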